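The source may hold more compounds than are shown below. What is called first, only, known or untested is meant among the compounds shown, and "the series" means these compounds.

In a functional assay on HCT-116 cells (Homo sapiens) for antiproliferative activity, with a stated time of 72 h (on this read-out higher numbers stand for weaker inhibition and lower numbers for stronger inhibition), compound 3 (`O=C(COc1ccc(CNC2CC=C(c3c[nH]c4ccccc34)CC2)c(F)c1)NO`) gives 436 nM. Its number lies within the scatter of compound 1 (`O=C(COc1ccc(CNC2CC=C(c3c[nH]c4ccc(F)cc34)CC2)c(F)c1)NO`), which gives 261 nM, while compound 2 (`Cc1[nH]c2ccccc2c1C1=CCC(NCc2ccc(OCC(=O)NO)cc2)CC1`), at 184 nM, gives a lower number, beyond the scatter.

The next compound, compound 4 (`Cc1[nH]c2ccccc2c1C1=CCC(NCc2ccc(OCC(=O)NO)cc2F)CC1`), changes compound 3 in one place: methyl in place of hydrogen on an aromatic carbon, turning 1H-indol-3-yl into 2-methyl-1H-indol-3-yl (methyl in place of hydrogen on an aromatic carbon).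

Going by the values given here, no measured step shows this change on its own. Among the compounds with values here, the only measured step is a 1.7-fold higher number from compound 1 to compound 3 (0.22 log units; within the scatter). Within the data shown here, it concerns a different swap, hydrogen in place of fluoro, so it shows only that one small change on this scaffold can leave the number within the scatter. The closest hint comes from compound 2, which already carries the 2-methyl-1H-indol-3-yl group but lacks a fluoro that compound 3 and compound 4 share. The value of compound 2 at 184 nM suggests a modest move towards a lower number, though the evidence is thin.

The expected size of the change is a 2.0-fold lower number from compound 3 to compound 4 (0.30 log units; within the scatter), and it may not clear the scatter. For compound 4, the estimated value is 220 nM, with an expected range from 90 nM to 500 nM.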

Compound 4, half-maximal inhibitory concentration: 99 nM
Beside the measured number, compound 4's estimate is 2.2-fold (0.35 log units) above it, within the range that was stated.
By their numbers in this assay, from the lowest: compounds 4, 2, 1 and 3 (each within the scatter of the next, the first and the last beyond it).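

Methyl on this aromatic carbon next to the ring nitrogen, which turns 1H-indol-3-yl into 2-methyl-1H-indol-3-yl, now has its own measured step in this assay, a 4.4-fold lower number from compound 3 to compound 4 (0.64 log units; beyond the scatter), and this single added carbon moves the number past the usual scatter. The 2-methyl-1H-indol-3-yl group also holds up against the 5-fluoro-1H-indol-3-yl group on the same core, with a 2.6-fold lower number from compound 1 to compound 4 (0.42 log units; beyond the scatter), so the methyl does more here than a fluoro placed elsewhere on that group. The fluoro that compound 2 lacks gives a smaller step that stays within the scatter, a 1.9-fold lower number from compound 2 to compound 4 (0.27 log units; within the scatter), and swapping fluoro and hydrogen reads much alike in both places where it can be followed: the same change on two cores in this assay, a 1.7-fold higher number (0.22 log units; within the scatter) from compound 1 to compound 3 and a 1.9-fold higher number (0.27 log units; within the scatter) from compound 4 to compound 2, 1.1-fold (0.05 log units) apart, within the scatter of two such steps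

On these data alone, the methyl step rests on a single pair of compounds, so its size on other cores remains open. As far as these compounds go, whether an ethyl, a methoxy or a chloro at this same carbon would extend the step or reverse it also remains open.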